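A Fluorine Shift on the Shared Core, Before Testing

This account rests on a few compounds, and the source may have more. Where it says the series, first, only, none or still open, it means among the compounds named here.

Of the compounds shown here, three have so far been measured in a functional assay on MDA-MB-231 cells (Homo sapiens) for antiproliferative activity, read by MTT assay, with a stated time of 72 h; a lower number here means a stronger inhibitor, a higher number a weaker inhibitor. Compound 1 `O=C(Nc1ccccc1C(=O)O/N=C1\CCCc2onc(-c3ccc(F)cc3)c21)c1cccc(F)c1` gives > 25000 nM, which is a limit of the assay and not a number. Compound 2 `O=C(Nc1cccc(C(=O)O/N=C2\CCCc3noc(-c4ccc(F)cc4)c32)c1)c1cccc(F)c1` likewise gives > 25000 nM, again a limit. Compound 3 `CC1(C)C/C(=N\OC(=O)c2cccc(NC(=O)c3cccc(F)c3)c2)c2c(-c3ccc(F)cc3)noc2C1` gives > 25000 nM, also a limit. Among the compounds with values here, compound 3 therefore stands where the other two stand, at the limit of > 25000 nM in this assay, at which 3 of the 3 values shown sit; none of the three is set apart from another, and no step between them can be sized.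

Compound 4 `CC1(C)C/C(=N\OC(=O)c2cccc(NC(=O)c3cccc(F)c3)c2)c2c(-c3cccc(F)c3)noc2C1` has not yet been measured. It differs from compound 3 in a single place: 3-fluorophenyl in place of 4-fluorophenyl on an aromatic carbon. Within the data shown here, no measured pair shows what this change does here, so there is no evidence from which to take a direction. With compound 3 at > 25000 nM, a limit, the step expected from compound 3 to compound 4 is a step that the limit leaves unreadable from compound 3 to compound 4, which is nothing beyond the scatter, and any movement in either direction would be hidden by the limit. The estimate for compound 4 in this assay is 40000 nM, with a range from 15000 nM to 120000 nM, and the most likely outcome is that the assay again reports only a limit.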

Compound 4, half-maximal inhibitory concentration: > 25000 nM
Compound 4 ended at the assay's limit (the forecaster's own chance of this, stated with the estimate: 85%); the middle value does not contradict the limit.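

In this assay, within the data shown here, compound 4 gives > 25000 nM which, like the result for compound 3, is a limit of the assay and not a number, so no step between compound 3 and compound 4 can be read: the limit of > 25000 nM in this assay, at which 4 of the 4 values shown sit. The compounds shown leave open whether in this assay any change to the shared core gives a readable number.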